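Another change of configuration at a ring carbon

This account rests on a few compounds, and the source may have more. Where it says the series, first, only, none or still open, it means among the compounds named here.

Compound 1 `O=C(O)[C@H]1[C@@H]2C[C@H](OC3CCN(c4ccc(-c5nc6cc(C(F)(F)F)ccc6[nH]5)cn4)CC3)C[C@@H]21` and compound 2 `O=C(O)[C@@H]1[C@@H]2C[C@H](OC3CCN(c4ccc(-c5nc6cc(C(F)(F)F)ccc6[nH]5)cn4)CC3)C[C@@H]21` are built from the same atoms and bonds, and they differ only in how one carbon is arranged in space. In a physicochemical assay for lipophilicity, read by HPLC (on this read-out higher numbers stand for higher lipophilicity and lower numbers for lower lipophilicity), compound 1 gives 1.9 and compound 2 gives 1.88. Only these two numbers exist so far, and they cannot be told apart, so compound 2 stands level with compound 1.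

The next structure is compound 3 `O=C(O)[C@@H]1[C@@H]2C[C@@H](OC3CCN(c4ccc(-c5nc6cc(C(F)(F)F)ccc6[nH]5)cn4)CC3)C[C@@H]21`. Its relation to compound 2 is simple to state: the two compounds have the same atoms and bonds and differ only in configuration as drawn: 1 of 4 stereo elements differ; a stereocentre at a saturated ring carbon is drawn r in compound 2 and s in compound 3. Nothing leaves and nothing enters, and only a stereocentre at a saturated ring carbon is drawn the other way.

Among the compounds with values here, one measured step bears on this, a number 0.02 log units lower from compound 1 to compound 2 (within the scatter), and it comes with the fact that compounds 1 and 2 differ only in the configuration as drawn. That step is of the same kind and is very small, although a single example is thin evidence. No shift beyond the scatter is therefore expected in either direction in this assay. The expected step is a number 0.02 log units higher from compound 2 to compound 3 (within the scatter). For compound 3 the estimated value is 1.9, with an expected range from 1.6 to 2.2.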

Compound 3, distribution coefficient: 1.73
Beside the measured number, compound 3's estimate is 0.17 log units above it; the range from low to high includes it.
By their numbers in this assay, from the lowest: compounds 3, 2 and 1 (each within the scatter of the next).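

A second stereocentre at a saturated ring carbon has now been turned over, and in this assay this too gives a step within the scatter: a number 0.15 log units lower from compound 2 to compound 3 (within the scatter). The earlier pair showed this for one stereocentre only, whereas here the two changes can also be read together, and with both stereocentres drawn the other way the step is still within the scatter: a number 0.17 log units lower from compound 1 to compound 3 (within the scatter). So all three arrangements remain indistinguishable in this assay, and the only structural difference to set beside that result is this: the fact that compounds 1 and 3 differ only in the configuration as drawn.

On these data alone, two of the four stereo elements have been varied here, so whether the other two would behave the same way remains open, as does whether this flat picture would hold with an amine or a nitrile in place of the carboxylic acid. These compounds also leave open whether configuration matters in any measurement other than this assay, since a shared reading here says nothing about how the three would compare elsewhere.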